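Taking a methoxy off a compound at the limit

This account rests on a few compounds, and the source may have more. Where it says the series, first, only, none or still open, it means among the compounds named here.

Compound 1 `N#C/C(=C\c1c[nH]c2ccccc12)C(=O)c1c[nH]c2ccccc12`: > 50000 nM
Compound 2 `COc1ccc(Cn2cc(/C=C(\C#N)C(=O)c3c[nH]c4cc(OC)ccc34)c3ccccc32)cc1`: > 50000 nM
Compound 3 `COc1ccc(Cn2cc(/C=C(\C#N)C(=O)c3c[nH]c4ccccc34)c3ccccc32)cc1`: not yet measured

In a functional assay on PC-3 cells (Homo sapiens) for cytotoxicity, read by WST assay, with a stated time of 24 h (on this read-out higher numbers stand for weaker inhibition and lower numbers for stronger inhibition), compound 2 gives > 50000 nM, which is a limit and not a number. Compound 1 gives > 50000 nM, also a limit. The measurements so far therefore show only (the limit of > 50000 nM in this assay, at which 2 of the 2 values shown sit).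

Compound 3 has hydrogen in place of methoxy on an aromatic carbon, the change from 6-methoxy-1H-indol-3-yl to 1H-indol-3-yl (hydrogen in place of methoxy on an aromatic carbon). No measured pair sizes this change, so no shift beyond the scatter is expected in this assay. The expected result is a number no higher from compound 2 to compound 3 (the limit leaves the size open). For compound 3 the estimate is 50000 nM, with an expected range of 15000 nM to 100000 nM.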

Compound 3, half-maximal inhibitory concentration: > 50000 nM
Compound 3 ended at the assay's limit (the forecaster's own chance of this, stated with the estimate: 75%); the middle value sits exactly at the limit.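

Going by these compounds alone, compound 1, compound 2 and compound 3 all stop at a limit rather than a number, so no step among them can be read: the limit of > 50000 nM in this assay, at which 3 of the 3 values shown sit.

On these data alone, how strongly any of them acts, and whether the methoxy or the 4-methoxybenzyl matters, stays open.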